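Working notes: methylsulfanyl in place of isopropoxy

The compounds below may be only part of what the source reports. "The series", "measured", "known", "first", "only" and "open" are said of these compounds alone.

In a functional assay on Jurkat cells (Homo sapiens) for antiproliferative activity, read by MTT assay, with a stated time of 72 h (on this read-out higher numbers stand for weaker inhibition and lower numbers for stronger inhibition), compound 1 `COc1ccc(-c2ncnn2-c2cc(OC)c(OC)c(OC)c2)cc1` gives 50 nM. Compound 2 `COc1cc(-n2ncnc2-c2ccccc2)cc(OC)c1OC` is reported only as a limit, > 10000 nM. Compound 3 `COc1cc(-n2ncnc2-c2ccc(OC(C)C)cc2)cc(OC)c1OC` gives 650 nM, the higher of the two actual numbers, with compound 1 its nearest neighbour. Compound 4 `COc1cc(-n2ncnc2-c2ccc(SC)cc2)cc(OC)c1OC` carries methylsulfanyl in place of isopropoxy on an aromatic carbon. Changes at this place have been large: an at least 200-fold higher number from compound 1 to compound 2 (2.30 log units; beyond the scatter), an at least 15-fold lower number from compound 2 to compound 3 (1.18 log units; beyond the scatter) and a 13-fold higher number from compound 1 to compound 3 (1.11 log units; beyond the scatter). Going by the values given here, the last is the closest guide, since methylsulfanyl bears a methyl as methoxy does, though no sulfur analogue has been measured. In this assay the expected step is large: a 5.4-fold lower number from compound 3 to compound 4 (0.73 log units; beyond the scatter). Compound 4 is expected at 120 nM, with an estimated range of 25 nM to 700 nM.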

Compound 4, half-maximal inhibitory concentration: 50 nM
Compound 4: the middle estimate sits 2.4-fold (0.38 log units) above what was measured; the range from low to high includes it.
By their numbers in this assay, from the lowest: compounds 1 and 4 (each within the scatter of the next); then compound 3. At a limit, above all of these: compound 2.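

In this assay, methylsulfanyl in place of isopropoxy gives a 13-fold lower number from compound 3 to compound 4 (1.11 log units; beyond the scatter), and methylsulfanyl in place of methoxy gives no change at the digits printed from compound 1 to compound 4 (within the scatter), so at this position a sulfur-linked methyl reads like the oxygen-linked one, and only the isopropoxy compound stands apart. With hydrogen on this carbon the step is an at least 200-fold lower number from compound 2 to compound 4 (2.30 log units; beyond the scatter), which is only a bound. Compound 2 is a limit, not a number: the limit of > 10000 nM in this assay, at which 1 of the 4 values shown sits.

The compounds shown leave open how an ethylsulfanyl chain or an amine on this carbon would read. They also leave open whether the match between methylsulfanyl and methoxy holds in other assays.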